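The source may hold more compounds than are shown below. What is called first, only, known or untested is meant among the compounds shown, and "the series" means these compounds.

Working notes on the series, read in an ADME assay on MT4 cells (Homo sapiens) for cytotoxicity, read by MTT assay, with a stated time of 4 days; on this read-out higher numbers stand for lower toxicity in this test and lower numbers for higher toxicity in this test. Compound 1 (`CCCN(C)c1nc(C(C)c2c(F)cccc2F)cc(=O)[nH]1`) gives > 81000 nM, which is a limit. Compound 2 (`Cc1c(C(C)c2c(F)cccc2F)nc(N(C)C)[nH]c1=O`) gives > 17000 nM, also a limit. Compound 3 (`CCCN(C)c1nc(C(C)c2c(F)cccc2F)c(C)c(=O)[nH]1`) gives > 78000 nM, again a limit, so it stands without a number, as do the other two. Compound 4 (`Cc1c(C(C)c2c(F)cccc2F)nc(N2CCC(C)CC2)[nH]c1=O`) differs from compound 3 by 4-methylpiperidin-1-yl in place of methyl(propyl)amino on an aromatic carbon, with 4-methylpiperidin-1-yl in place of methyl(propyl)amino on an aromatic carbon. The measured steps touching compound 3 are a step that the two limits leave unreadable from compound 1 to compound 3 and a step that the two limits leave unreadable from compound 2 to compound 3. Neither gives a size or a direction, so no shift beyond the scatter is expected. The expected step is an at least 1.3-fold lower number from compound 3 to compound 4 (0.11 log units; that floor lies within the scatter). Compound 4 is estimated at 60000 nM. Its expected range runs from 15000 nM to 100000 nM.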

Compound 4, half-maximal cytotoxic concentration: 54000 nM
Estimate against measurement, compound 4: 1.1-fold (0.05 log units) above, and the stated range covers the measured number.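

In this assay the change to 4-methylpiperidin-1-yl on the aromatic carbon between two ring nitrogen atoms gives the only number in the series shown that is not a limit. The step reads as an at least 1.4-fold lower number from compound 3 to compound 4 (0.15 log units; that floor lies within the scatter), so only a floor on its size is known. The step to this compound from compound 2 cannot be read, because compound 2 carries only a limit: the limit of > 17000 nM in this assay, at which 1 of the 4 values shown sits.

Left open is whether a morpholine or a piperazine in this place would give a number beyond the scatter from compound 4.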